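Hydroxy to Bromo on the Anilino Ring: an Expected Value

This account rests on a few compounds, and the source may have more. Where it says the series, first, only, none or still open, it means among the compounds named here.

Compound 1 `COc1cc2c(Nc3ccc(F)cc3)ncnc2c(OC)c1OC`: 39600 nM
Compound 2 `COc1cc2c(N[C@@H](C)c3ccccc3)ncnc2c(OC)c1OC`: 11900 nM
Compound 3 `COc1cc2c(Nc3ccc(O)cc3)ncnc2c(OC)c1OC`: 35400 nM

These three compounds share one core and were tested in a functional assay on BGC-823 cells (Homo sapiens) for inhibition, read by MTT assay, with a stated time of 72 h; a higher number here means a weaker inhibitor, a lower number a stronger inhibitor. Compound 3 has the second highest number of the three: the step of a 1.1-fold lower number from compound 1 to compound 3 (0.05 log units; within the scatter) stays within the scatter, while a 3.0-fold higher number from compound 2 to compound 3 (0.47 log units; beyond the scatter) lies beyond it.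

Compound 4 `COc1cc2c(Nc3ccc(Br)cc3)ncnc2c(OC)c1OC` differs from compound 3 by bromo in place of hydroxy on an aromatic carbon. Going by the values given here, the only measured step at that same position is a 1.1-fold lower number from compound 1 to compound 3 (0.05 log units; within the scatter), which was within the scatter. Among the compounds with values here, no measured compound carries a bromo group, so nothing more can be drawn on. The expected step is therefore none beyond the scatter, a 1.0-fold lower number from compound 3 to compound 4 (0.00 log units; within the scatter). Compound 4 is estimated at 35000 nM in this assay, with a range of 12000 nM to 100000 nM.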

Compound 4, half-maximal inhibitory concentration: 23800 nM
The estimate for compound 4 lay 1.5-fold (0.17 log units) above the measured number, within the range that was stated.
By their numbers in this assay, from the lowest: compounds 2, 4, 3 and 1 (each within the scatter of the next, the first and the last beyond it).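

Bromo in place of hydroxy gives a 1.5-fold lower number from compound 3 to compound 4 (0.17 log units; within the scatter), and bromo in place of fluoro gives a 1.7-fold lower number from compound 1 to compound 4 (0.22 log units; within the scatter), so in this assay these three groups on the aromatic carbon cannot be told apart. The step of a 2.0-fold higher number from compound 2 to compound 4 (0.30 log units; within the scatter) also stays within the scatter, unlike the steps linking compound 2 to the fluoro and hydroxy compounds. Nothing measured here bears on the reason for these results.

As far as these compounds go, whether an amine, a carboxylic acid or a longer chain at this position would move the number beyond the scatter remains open.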